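The source may hold more compounds than are shown below. What is called first, only, known or untested is meant among the compounds shown, and "the series" means these compounds.

Series notes. In a functional assay on the whole organism with Rattus norvegicus as the target, at a dose of 100 mg/kg (a higher number here means more inhibition at the dose given (going by the name of the read-out), a lower number less inhibition), compound 1 `CC/N=C(\S)NCCCCCCn1nc(-c2ccccc2)ccc1=O` gives -5.6%. Compound 2 `CC/N=C(\S)NCCCCCn1nc(-c2ccccc2)ccc1=O` gives 66.4%. Among the measured compounds shown here, the single measured step runs a number 72 percentage points higher from compound 1 to compound 2 (beyond the scatter). Compound 3 `O=c1ccc(-c2ccccc2)nn1CCCCNC(=S)NC1CCCCC1` gives 18.1%. Among the three numbers compound 3 stands second highest; its nearest neighbour is compound 1, lower by a margin beyond the scatter, and its furthest is compound 2, higher by a margin beyond the scatter.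

Compound 4 `CC/N=C(/NC#N)NCCCCn1nc(-c2ccccc2)ccc1=O` differs from compound 3 in one place: a group of 7 heavy atoms (4 carbon, 3 nitrogen; no ring) in place of a group of 9 heavy atoms (7 carbon, 1 nitrogen, 1 sulfur; one six-membered non-aromatic ring of carbon only), on an amine nitrogen. For the measured compounds named here, the only measured step concerns the chain carrying the thiourea, not the group on the amine nitrogen, so it does not bear on this change, and no step beyond the scatter in either direction is expected in this assay. Near the value of compound 3, compound 4 is expected at 20%, ranging from -10% to 55%. This expectation corresponds to a number 1.9 percentage points higher from compound 3 to compound 4 (within the scatter).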

Compound 4, a percentage reported as inhibition, in the whole organism at one dose (the size of the read-out at that dose, not a potency): 58.8%
The estimate for compound 4 lay 38.8 percentage points below the measured number; the whole stated range lies below it.
By their numbers in this assay, from the lowest: compound 1; then compound 3; then compounds 4 and 2 (each within the scatter of the next).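

In this assay the change on the amine nitrogen gives a number 40.7 percentage points higher from compound 3 to compound 4 (beyond the scatter), so the group at this place moves the number as well as the chain does. The other two steps, a number 7.6 percentage points lower from compound 2 to compound 4 (within the scatter) and a number 64.4 percentage points higher from compound 1 to compound 4 (beyond the scatter), put the entering group with its triple bond level with compound 2 and well clear of compound 1. No measurement here bears on what lies behind these steps.

Open, going by these compounds, is whether the step follows the loss of the ring or the loss of the sulfur. Also open, on these data alone, is whether a urea carbonyl or a benzyl group on the amine nitrogen would hold the number.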